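The compounds below may be only part of what the source reports. "The series", "measured", "known", "first", "only" and "open" are said of these compounds alone.

Measured in a functional assay on HCT-116 cells (Homo sapiens) for antiproliferative activity, read by MTT assay, with a stated time of 48 h; a lower number here means a stronger inhibitor, a higher number a weaker inhibitor:
Compound 1 `COc1ccc(-c2cncc3[nH]c(=O)n(Cc4cc(OC)c(OC)c(OC)c4)c23)cc1`: > 20000 nM
Compound 2 `COc1ccc(-c2cc3c(cn2)[nH]c(=O)n3-c2cc(OC)c(OC)c(OC)c2)cn1`: 830 nM

The entry for compound 1 is a limit of the assay and not a number. Within the data shown here, that leaves compound 2, at 830 nM, as the only compound here with an actual number, and so the natural point of comparison.

Compound 3 `COc1ccc(-c2cc3c(cn2)[nH]c(=O)n3-c2cc(OC)c(OC)c(OC)c2)cc1C(=O)O` keeps the core of compound 2 and changes one group: 3-carboxy-4-methoxyphenyl in place of 6-methoxypyridin-3-yl on an aromatic carbon, next to the ring nitrogen (3-carboxy-4-methoxyphenyl in place of 6-methoxypyridin-3-yl on an aromatic carbon). Among the measured compounds shown here, no pair of measured compounds differs in one place only, so no measured step in this assay speaks directly to this swap, and the expectation is a rough one. The swap replaces a whole ring and adds a carboxy group with its hydrogen-bond donor, so a weakening beyond the usual scatter is expected, moderate in size rather than a complete loss. The expected change is a 4.8-fold higher number from compound 2 to compound 3 (0.68 log units; beyond the scatter). For compound 3 the estimated value is 4000 nM, with an expected range from 1200 nM to 20000 nM.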

Compound 3, half-maximal inhibitory concentration: 3070 nM
Compound 3: middle estimate off by 1.3-fold (0.11 log units), on the high side; the range from low to high includes it.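

Among these compounds, the swap of 6-methoxypyridin-3-yl for 3-carboxy-4-methoxyphenyl gives the first measured single-place change in this set, in this assay: a 3.7-fold higher number from compound 2 to compound 3 (0.57 log units; beyond the scatter). This shows that the aromatic carbon next to the ring nitrogen is sensitive to what it carries, yet it can hold the larger group, with its carboxy hydrogen-bond donor, at the cost of a modest weakening and not a complete loss of activity. Compound 1 alone sits at the limit of the assay, while compound 3 remains a real number: the limit of > 20000 nM in this assay, at which 1 of the 3 values shown sits.

This single step changes two things at once, since the ring nitrogen of the pyridine leaves and a carboxy group enters, so the compounds shown cannot tell how much of the weakening belongs to each. A plain 4-methoxyphenyl group at this position would isolate the effect of losing the ring nitrogen, and a methyl ester or a primary amide in place of the carboxylic acid would show whether the acid itself matters.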